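Activity in the maximal electroshock model: compound 1 to compound 4

A few compounds are considered here, and "the series" means these few. Any claim that something is new, unique, unknown or untested is made for them only; others in the source may bear on it.

Measured so far:
compound 1, `COc1cccc(N2CCN(C(=O)C(C)N3C(=O)CCC3=O)CC2)c1`, 50%
compound 2, `COCC(C(=O)N1CCN(c2cccc(C(F)(F)F)c2)CC1)N1C(=O)CCC1=O`, 50%
compound 3, `CCC(C(=O)N1CCN(c2ccccc2)CC1)N1C(=O)CCC1=O`, 75%

Of the compounds shown here, three that share a core have been tested in a functional assay on the whole organism (strain Swiss) with Mus musculus as the target, in the maximal electroshock model, with a stated time of 0.5 h, at a dose of 300 mg/kg by the intraperitoneal route; a higher number here means a stronger effect of the compound at the dose given, a lower number a weaker effect. In this assay compound 1 gives 50%, and compound 2 gives 50%, the same number at the digits printed, so the two sit level and within the scatter of each other; together they are the lowest two of the three numbers. Compound 3 gives 75%, a number above compound 1 by a difference that is beyond the scatter. Among the compounds with values here, no step between two measured compounds that differ in one place is known here, so nothing about the size of a single change is established from these three.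

Compound 4, `CC(C(=O)N1CCN(c2ccc(Cl)cc2)CC1)N1C(=O)CCC1=O`, has not been measured in this assay. It differs from compound 1 in one place: 4-chlorophenyl in place of 3-methoxyphenyl on an amine nitrogen in a ring. Within the data shown here, nothing among the measured compounds shows what this exchange does. The step from compound 1 to compound 4 is therefore expected to be small, possibly none beyond the scatter, and if anything slightly upward. Compound 4 is expected to give about 60%, with a range from 40% to 85%. This estimate for compound 4 means a step of a number 10 percentage points higher from compound 1 to compound 4 (within the scatter), expected to stay within or near the scatter.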

Compound 4, a percentage reported as activity, at one dose (the size of the read-out at that dose, not a potency): 100%
Compound 4: the middle estimate sits 40 percentage points below what was measured, outside the stated range (above it).
By their numbers in this assay, from the lowest: compounds 1 and 2 (each within the scatter of the next); then compound 3; then compound 4.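

In this assay, replacing 3-methoxyphenyl with 4-chlorophenyl on the amine nitrogen in a ring gives a number 50 percentage points higher from compound 1 to compound 4 (beyond the scatter), so this position can carry a large change in the read-out while the rest of the molecule stays the same. The earlier compounds shown here offered no comparison of this kind, and this single step now shows that the choice of aryl group here is not a neutral one at this dose. Nothing available explains why the exchange has so large an effect, although the count shows that the hydrogen-bond acceptor of the leaving group has no counterpart in the entering one.

The step changes the kind of substituent and its place on the phenyl ring at once, so it cannot show whether the loss of the methoxy group, the arrival of the chlorine or the change of place accounts for the rise. The compounds shown also leave open whether a bromophenyl or a pyridyl group at this position would hold the effect, and, since this is a read-out at one dose, how compound 1 and compound 4 differ in potency.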